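The compounds below may be only part of what the source reports. "The series", "measured", "known", "first", "only" and "open" are said of these compounds alone.

Of the compounds shown here, three that share one core have been measured in a functional assay (Oryctolagus cuniculus) for antagonist activity at platelet-activating factor receptor (Cavia porcellus); a lower number here means a stronger inhibitor, a higher number a weaker inhibitor. Compound 1 `CN(C)C(=O)n1cc(C(=O)c2ccn3c2CSC3c2cccnc2)c2ccccc21` carries hydrogen at the position in question, and in this assay compound 1 gives 95 nM. Compound 2 `CN(C)C(=O)n1cc(C(=O)c2ccn3c2CSC3c2cccnc2)c2ccc(Cc3ccccc3)cc21` carries benzyl there, and compound 2 gives 13 nM. Compound 3 `CN(C)C(=O)n1cc(C(=O)c2ccn3c2CSC3c2cccnc2)c2ccc(-c3ccccc3)cc21` carries phenyl there, and compound 3 gives 23 nM. The steps are a 7.3-fold lower number from compound 1 to compound 2 (0.86 log units; beyond the scatter) and a 4.1-fold lower number from compound 1 to compound 3 (0.62 log units; beyond the scatter), while a 1.8-fold higher number from compound 2 to compound 3 (0.25 log units; within the scatter). Compound 3 thus stands second highest of the three numbers, close to compound 2 and well away from compound 1.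

Compound 4 `CN(C)C(=O)n1cc(C(=O)c2ccn3c2CSC3c2cccnc2)c2ccc(Sc3ccc(F)cc3)cc21` is not yet measured. It differs from compound 3 in one place: (4-fluorophenyl)sulfanyl in place of phenyl on an aromatic carbon. Both measured steps from compound 1 show that an aromatic group at this position lowers the number, and the benzyl and phenyl analogues sit within the scatter of each other, so a further aromatic group on a one-atom link is expected to give a number near those two. Compound 4 is therefore estimated at 15 nM, with a range from 6 nM to 45 nM, which would mean an expected step of a 1.5-fold lower number from compound 3 to compound 4 (0.19 log units; within the scatter).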

Compound 4, inhibition constant: 17 nM
Estimate against measurement, compound 4: 1.1-fold (0.05 log units) below; measured number inside the range.
By their numbers in this assay, from the lowest: compounds 2, 4 and 3 (each within the scatter of the next); then compound 1.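

Measured in this assay, replacing phenyl with (4-fluorophenyl)sulfanyl leaves the number within the scatter (a 1.4-fold lower number from compound 3 to compound 4 (0.13 log units; within the scatter)), and the same holds against the benzyl analogue (a 1.3-fold higher number from compound 2 to compound 4 (0.12 log units; within the scatter)). The gain over hydrogen remains beyond the scatter (a 5.6-fold lower number from compound 1 to compound 4 (0.75 log units; beyond the scatter)), so all three aromatic groups at this position lower the number, and a sulfur link with a fluorine on the ring fits that pattern with none of the listed compounds going against it. No measurement here bears on why these three groups read alike.

The effects of the sulfur and the fluorine cannot be separated, since the compounds shown include neither plain phenylsulfanyl nor a benzyl group carrying fluorine. Going by these compounds, it also remains open whether the lower number requires an aromatic ring at all, as an amine, a carboxylic acid or a longer alkyl chain at this position would show.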